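Growing the Amide Nitrogen Substituent from Compound 1 to Compound 3

The compounds below may be only part of what the source reports. "The series", "measured", "known", "first", "only" and "open" are said of these compounds alone.

Compound 1, `CNC(=O)CSc1nc2ccc(NC(=O)c3ccccc3OC)cc2s1`, gives 18500 nM in a functional assay on HepG2 cells (Homo sapiens) for cytotoxicity, read by MTT assay, with a stated time of 48 h; a higher number here means a weaker inhibitor, a lower number a stronger inhibitor. Compound 2, `CNC(=O)CSc1nc2ccc(NC(C)=O)cc2s1`, reaches only a limit of this assay, > 100000 nM.

Compound 1 thus holds the only number shown in this assay; the other value is a limit. Among the measured compounds shown here, the one measured step, an at least 5.4-fold higher number from compound 1 to compound 2 (0.73 log units; beyond the scatter), changes the carbonyl substituent on the ring-bound amide, and compound 2 sits at the limit described by the limit of > 100000 nM in this assay, at which 1 of the 2 values shown sits. Compound 3, `COc1ccc(CNC(=O)CSc2nc3ccc(NC(=O)c4ccccc4OC)cc3s2)cc1`, differs from compound 1 elsewhere: 4-methoxyphenyl in place of hydrogen on a saturated chain carbon bound to an amide-type nitrogen. For the measured compounds named here, no measured step touches that position, so the step from compound 1 to compound 2 gives no direct guide, and a change of at most modest size is expected, in either direction or none beyond the scatter. Compound 3 is therefore expected to give about 12000 nM, between 4000 nM and 40000 nM, an expected step of a 1.5-fold lower number from compound 1 to compound 3 (0.19 log units; within the scatter).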

Compound 3, half-maximal inhibitory concentration: 2100 nM
Estimate against measurement, compound 3: 5.7-fold (0.76 log units) above; measured number below the stated range.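

The step shows that the amide nitrogen substituent, which the earlier step did not touch, responds in this assay: 4-methoxyphenyl in place of hydrogen on a saturated chain carbon bound to an amide-type nitrogen gives an 8.8-fold lower number from compound 1 to compound 3 (0.94 log units; beyond the scatter). The earlier comparison spoke only to the carbonyl substituent on the ring-bound amide, whereas this one shows that methylamino can be replaced by (4-methoxybenzyl)amino, adding 8 heavy atoms, and that the number falls rather than rises. Nothing measured here accounts for this drop.

The compounds shown leave open whether the methoxy group takes part or the phenyl ring alone suffices, as a plain benzyl group would tell, and how a longer chain such as phenethyl or an amine on the ring would read. On these data alone, whether the same change would carry over to compound 2, whose value is only a limit, also stays open.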